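Amino in place of nitro: what to expect

A few compounds are considered here, and "the series" means these few. Any claim that something is new, unique, unknown or untested is made for them only; others in the source may bear on it.

compound 1 `CCOc1ccc(Cl)cc1-c1ncc(C(=O)O)c(=O)[nH]1`: 0.5 mg/kg
compound 2 `CCOc1ccc(C(=O)O)cc1-c1ncc(C(=O)O)c(=O)[nH]1`: 25 mg/kg
compound 3 `CCOc1ccc([N+](=O)[O-])cc1-c1ncc(C(=O)O)c(=O)[nH]1`: 25 mg/kg

In a functional assay on the whole organism (strain Sprague-Dawley) for inhibition, with Rattus norvegicus as the target, with a stated time of 10 min (on this read-out lower numbers stand for an effect already at smaller amounts and higher numbers for an effect only at larger amounts of compound), compound 2 and compound 3 stand level, together holding the highest number of the three, with compound 3 at 25 mg/kg. Compound 4 `CCOc1ccc(N)cc1-c1ncc(C(=O)O)c(=O)[nH]1`, not yet measured, carries amino in place of nitro on an aromatic carbon, para to an ethoxy group: amino in place of nitro on an aromatic carbon.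

Among the compounds with values here, three measured steps bear on this change, all made at the same place. Carboxy in place of chloro gave a 50-fold higher number from compound 1 to compound 2 (1.70 log units; beyond the scatter), and nitro in place of chloro gave a 50-fold higher number from compound 1 to compound 3 (1.70 log units; beyond the scatter). Nitro in place of carboxy gave no change at the digits printed from compound 2 to compound 3 (within the scatter). So this place can produce a large step, but two quite different groups can also read alike. None of the three compounds carries amino, so the direction remains uncertain. Within the data shown here, the only low number belongs to compound 1 at 0.5 mg/kg, which suggests a modest move towards lower numbers, well short of that value. The expected step is a 2.5-fold lower number from compound 3 to compound 4 (0.40 log units; beyond the scatter). For compound 4 the estimate is 10 mg/kg, with an expected range from 1.5 mg/kg to 40 mg/kg.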

Compound 4, dose for 50% inhibition: 1.2 mg/kg
The estimate for compound 4 lay 8.3-fold (0.92 log units) above the measured number, and the stated range ends above it.
By their numbers in this assay, from the lowest: compound 1; then compound 4; then compounds 2 and 3 (each within the scatter of the next).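

In this assay, amino in place of nitro gave a 21-fold lower number from compound 3 to compound 4 (1.32 log units; beyond the scatter), and amino in place of carboxy gave a step of the same printed size, a 21-fold lower number from compound 2 to compound 4 (1.32 log units; beyond the scatter). Among the earlier compounds only chloro stood low at this place, para to an ethoxy group, so the result shows that a low number here does not belong to chloro alone and that a single change at this carbon can take back most of the large distance between the two ends of the series. Amino still does not fully match chloro, however, since replacing chloro with amino gave a 2.4-fold higher number from compound 1 to compound 4 (0.38 log units; beyond the scatter), a modest step but one beyond the scatter. Nothing among the data shown explains why amino reads so differently from nitro and carboxy at this position.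

As far as these compounds go, whether low numbers here extend beyond amino and chloro remains open, as a hydroxy group, a methylamino group, an acetylamino group or bromo could fall on either side at the same carbon. Also open, from the compounds shown here alone, is whether these steps would keep their size if the ethoxy group, common to all four compounds, gave way to methoxy or a longer chain.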